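Changing the aryl group on the amine nitrogen

The source may report more compounds than this note shows. Statements on the series, on what has been measured and on what is new or still open speak of the compounds shown alone.

Of the compounds shown here, three that share one core have been measured in a functional assay on HeLa cells (Homo sapiens) for cytotoxicity, read by MTT assay, with a stated time of 48 h; a higher number here means a weaker inhibitor, a lower number a stronger inhibitor. Compound 1 `Cc1ccc(S(=O)(=O)/N=C(/CCNC2=CC(=O)c3ccccc3C2=O)Nc2ccccc2I)cc1` gives 19100 nM. Compound 2 `Cc1ccc(S(=O)(=O)/N=C(/CCNC2=CC(=O)c3ccccc3C2=O)Nc2cccc(C)c2)cc1` gives 9060 nM, and compound 3 `Cc1ccc(S(=O)(=O)/N=C(/CCNC2=CC(=O)c3ccccc3C2=O)Nc2ccc(F)c(F)c2)cc1` gives 8790 nM. Going by the values given here, compound 3 thus carries the lowest of the three numbers, but its gap to compound 2 is within the scatter, so those two cannot be ranked against each other; only the step of a 2.2-fold lower number from compound 1 to compound 3 (0.34 log units; beyond the scatter) is a difference that can be trusted, and a 2.1-fold lower number from compound 1 to compound 2 (0.32 log units; beyond the scatter) is of the same size. The step of a 1.0-fold lower number from compound 2 to compound 3 (0.01 log units; within the scatter) shows that trading one substituent pattern on this ring for another produced no difference beyond the scatter.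

Compound 4 `COc1ccc(N/C(CCNC2=CC(=O)c3ccccc3C2=O)=N\S(=O)(=O)c2ccc(C)cc2)c(OC)c1` is the next variation at the same position: 2,4-dimethoxyphenyl in place of 3,4-difluorophenyl on an amine nitrogen. Among the compounds with values here, none of the measured compounds carries methoxy groups, so there is no direct precedent for this change. What the measured steps do show is that alterations on this ring have shifted the number only modestly, at most by the size of a 2.2-fold lower number from compound 1 to compound 3 (0.34 log units; beyond the scatter). The expectation for compound 4 is therefore a small step, about a 1.3-fold higher number from compound 3 to compound 4 (0.10 log units; within the scatter), which may well stay within the scatter, with a slight lean toward a higher number. Compound 4 is estimated to give 11000 nM in this assay, with a likely range from 4500 nM to 27000 nM.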

Compound 4, half-maximal inhibitory concentration: 67600 nM
Compound 4: the middle estimate sits 6.1-fold (0.79 log units) below what was measured, and the stated range ends below it.
By their numbers in this assay, from the lowest: compounds 3 and 2 (each within the scatter of the next); then compound 1; then compound 4.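

Until now, changing the aryl group on this amine nitrogen had moved the number only modestly, but in this assay the 2,4-dimethoxyphenyl group brings a 7.7-fold higher number from compound 3 to compound 4 (0.89 log units; beyond the scatter), and a 7.5-fold higher number from compound 2 to compound 4 (0.87 log units; beyond the scatter) is of the same size, so this position tolerates less variation than compound 1, compound 2 and compound 3 alone suggested. The 2-iodophenyl group no longer marks the weak end of the set, as there is also a 3.5-fold higher number from compound 1 to compound 4 (0.55 log units; beyond the scatter), and with all three of its steps beyond the scatter, compound 4 is the weakest of the four. Nothing available accounts for this loss, neither for the methoxy groups themselves nor for where they sit on the ring.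

On these data alone, it remains open whether a phenyl ring with a single methoxy group would behave like compound 4, and whether a hydroxyl group or an amine in place of methoxy would give a similar number. Only this aryl group varies among the compounds shown, so it is also unknown how a plain alkyl chain on this nitrogen would compare, or whether the same change would act the same way on a different core.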